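Swapping the chloro substituent for trifluoromethoxy

The source may hold more compounds than are shown below. What is called first, only, known or untested is meant among the compounds shown, and "the series" means these compounds.

Of the two compounds measured in an assay on CHO cells for displacement of a labelled ligand from Glucagon receptor (Homo sapiens), read by scintillation counting, with a stated time of 60 min (on this read-out lower numbers stand for stronger inhibition and higher numbers for weaker inhibition), compound 2 `C[C@H](c1ccc(C(=O)NCCC(=O)O)cc1)N1C(=O)C(c2cccc(Cl)c2)=N[C@]12CC[C@@H](C(C)(C)C)CC2` stands with the higher number, at 130 nM; compound 1 `C[C@H](c1ccc(C(=O)NCCC(=O)O)cc1)N1C(=O)C(c2cccc(C3CC3)c2)=N[C@]12CC[C@@H](C(C)(C)C)CC2` gives 56 nM, and the step of a 2.3-fold higher number from compound 1 to compound 2 (0.37 log units; beyond the scatter) separates them. Compound 3 `C[C@H](c1ccc(C(=O)NCCC(=O)O)cc1)N1C(=O)C(c2cccc(OC(F)(F)F)c2)=N[C@]12CC[C@@H](C(C)(C)C)CC2` differs from compound 2 by trifluoromethoxy in place of chloro on an aromatic carbon. For the measured compounds named here, only the step from compound 1 to compound 2 touches this position, and it concerned a different exchange, so it gives no more than a loose guide. Compound 3 is therefore expected to land close to compound 2, with a step of a 1.6-fold lower number from compound 2 to compound 3 (0.21 log units; within the scatter) and an estimate of 80 nM in a range of 30 nM to 200 nM.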

Compound 3, half-maximal inhibitory concentration: 330 nM
Estimate against measurement, compound 3: 4.1-fold (0.62 log units) below; measured number above the stated range.
By their numbers in this assay, from the lowest: compound 1; then compound 2; then compound 3.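

In this assay this position proves sensitive to the exchange, as trifluoromethoxy in place of chloro gives a 2.5-fold higher number from compound 2 to compound 3 (0.40 log units; beyond the scatter) and so does not hold the level of compound 2. Trifluoromethoxy in place of cyclopropyl gives a wider gap, a 5.9-fold higher number from compound 1 to compound 3 (0.77 log units; beyond the scatter), and the three compounds rise in the order cyclopropyl, chloro, trifluoromethoxy. Nothing available explains this order. Going by these compounds, whether a methyl, methoxy or nitrile at this place would fall nearer compound 1 or compound 3 remains open.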